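A few compounds are considered here, and "the series" means these few. Any claim that something is new, unique, unknown or untested is made for them only; others in the source may bear on it.

Compound 2 `CCOC(=O)C1=C(N)OC(C)=C(C(=O)OC)C1c1cccc([N+](=O)[O-])c1` sits in the middle of three measured compounds. In an assay on HEK293 cells for antagonist activity at Voltage-dependent L-type calcium channel subunit alpha-1D (Rattus norvegicus), read by FLIPR (on this read-out higher numbers stand for weaker inhibition and lower numbers for stronger inhibition), compound 2 gives 2720 nM. Compound 3 `COC(=O)C1=C(C)OC(N)=C(C(=O)OC(C)C)C1c1cccc([N+](=O)[O-])c1` differs from it only by a methyl in place of hydrogen on a saturated chain carbon bound to an oxygen next to a carbonyl group and a saturated chain carbon, and in this assay compound 3 gives 1820 nM, so that a 1.5-fold lower number from compound 2 to compound 3 (0.17 log units; within the scatter). Compound 1 `COC(=O)C1=C(C(C)C)NC(=O)N(C(=O)OC(C)C)C1c1cccc([N+](=O)[O-])c1` has a different core; in this assay compound 1 gives 10100 nM, the highest number of the three, and its gap to compound 2 lies beyond the scatter.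

Compound 4 `CCOC(=O)C1=C(NC(=O)C(C)C)OC(C)=C(C(=O)OC)C1c1cccc([N+](=O)[O-])c1` has not yet been measured. It differs from compound 2 in one place: isopropylcarbonyl in place of hydrogen on an amine nitrogen. Among the compounds with values here, no measured step touches this amine nitrogen; the only single step on hand, from compound 2 to compound 3, concerns an ester and stays within the scatter, so it gives no guidance on what an isopropylcarbonyl on the nitrogen does. With nothing to anchor a shift, the expectation for compound 4 is a number close to that of compound 2, and this estimate means a 1.1-fold higher number from compound 2 to compound 4 (0.04 log units; within the scatter). Compound 4 is therefore estimated at 3000 nM, with a wide range from 800 nM to 12000 nM.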

Compound 4, half-maximal inhibitory concentration: 9950 nM
Estimate against measurement, compound 4: 3.3-fold (0.52 log units) below, within the range that was stated.
By their numbers in this assay, from the lowest: compounds 3 and 2 (each within the scatter of the next); then compounds 4 and 1 (each within the scatter of the next).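

The amine nitrogen turns out to be a place where a change registers: in this assay, isopropylcarbonyl in place of hydrogen gives a 3.7-fold higher number from compound 2 to compound 4 (0.56 log units; beyond the scatter). Within the data shown here, this is the first single change to go beyond the scatter, and its direction is towards weaker inhibition, whereas the ester change in a 1.5-fold lower number from compound 2 to compound 3 (0.17 log units; within the scatter) stayed within it, so the free amino group matters more to this read-out than that ester difference does. The data show the size and direction of the shift but offer no measurement that explains it, and nothing here separates the loss of the amine hydrogen from the presence of the added group.

One pair cannot tell whether any group on this nitrogen would give the same shift, or whether an acetyl, a longer acyl chain or a simple methyl would leave the number nearer to that of compound 2. From the compounds shown here alone, it also remains open whether the same change would give a similar step with the isopropyl ester of compound 3.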